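A few compounds are considered here, and "the series" means these few. Any claim that something is new, unique, unknown or untested is made for them only; others in the source may bear on it.

Compound 2 `O=c1cc(Nc2ccccc2)cc(-c2ccccc2)o1` carries a phenyl on the nitrogen of the shared core. In a functional assay on DU-145 cells (Homo sapiens) for cytotoxicity, read by MTT assay, with a stated time of 72 h (a higher number here means that more compound is needed for the effect, a lower number that less compound is needed), compound 2 gives 0.098 uM, the highest of the two numbers measured. Its nearest neighbour is compound 3 `Cc1ccc(Nc2cc(-c3ccccc3)oc(=O)c2)cc1`, which in this assay gives 0.073 uM; the step of a 1.3-fold lower number from compound 2 to compound 3 (0.13 log units; within the scatter) lies within the scatter. Compound 1 `O=c1cc(NC2CC2)cc(-c2ccccc2)o1`, with cyclopropyl on that nitrogen, gives only a limit in this assay, > 30 uM. From compound 1 the steps of an at least 300-fold lower number from compound 1 to compound 2 (2.48 log units; beyond the scatter) and an at least 410-fold lower number from compound 1 to compound 3 (2.61 log units; beyond the scatter) are large. Compound 4 `COc1ccccc1Nc1cc(-c2ccccc2)oc(=O)c1` differs from compound 2 by methoxy in place of hydrogen on an aromatic carbon. The closest measured step, a methyl added to the same aromatic ring, stayed within the scatter, so no step beyond the scatter is expected for compound 4. The expected step is a 1.5-fold higher number from compound 2 to compound 4 (0.18 log units; within the scatter). Compound 4 is estimated at 0.15 uM, with a range from 0.04 uM to 0.6 uM.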

Compound 4, concentration for half-maximal effect: 0.37 uM
Beside the measured number, compound 4's estimate is 2.5-fold (0.39 log units) below it; the range from low to high includes it.
By their numbers in this assay, from the lowest: compounds 3 and 2 (each within the scatter of the next); then compound 4. At a limit, above all of these: compound 1.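

For the compounds shown here, on this ring, replacing a hydrogen does not always leave the number unchanged: methoxy on an aromatic carbon ortho to a large group gives a 3.8-fold higher number from compound 2 to compound 4 (0.58 log units; beyond the scatter) in this assay and is the first such change to pass the scatter. The methyl step, a 1.3-fold lower number from compound 2 to compound 3 (0.13 log units; within the scatter), did not pass it. Nothing measured here explains this rise.

As far as these compounds go, it remains open whether the rise belongs to methoxy itself or to the place it occupies. A chlorine or a hydroxy on that same carbon, or a methoxy elsewhere on the ring, would help separate the two.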